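The source may hold more compounds than are shown below. What is called first, only, known or untested is meant among the compounds shown, and "the series" means these compounds.

Compound 1 `COc1cc(C(=O)c2sc3ccccc3c2-c2ccccc2)cc(OC)c1OC`: 5000 nM
Compound 2 `COc1ccc(-c2c(C(=O)c3cc(OC)c(OC)c(OC)c3)sc3ccccc23)cc1`: 4400 nM

In a functional assay on A549 cells (Homo sapiens) for antiproliferative activity, read by MTT assay, with a stated time of 72 h (on this read-out higher numbers stand for weaker inhibition and lower numbers for stronger inhibition), compound 2, at 4400 nM, stands within the scatter of compound 1. Compound 3 `COc1ccc(-c2c(C(=O)c3cc(OC)c(OC)c(OC)c3)sc3ccccc23)c(OC)c1` differs from compound 2 by one change: methoxy in place of hydrogen on an aromatic carbon, taking 4-methoxyphenyl to 2,4-dimethoxyphenyl. Within the data shown here, the one measured step of this kind, a 1.1-fold lower number from compound 1 to compound 2 (0.06 log units; within the scatter), stayed within the scatter, although it does not involve this place. No shift beyond the scatter is therefore expected in this assay. For compound 3 the estimated value is 4000 nM, with an expected range of 1500 nM to 10000 nM. This estimate means an expected 1.1-fold lower number from compound 2 to compound 3 (0.04 log units; within the scatter).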

Compound 3, half-maximal inhibitory concentration: 5800 nM
Compound 3: the middle estimate sits 1.5-fold (0.16 log units) below what was measured; the range from low to high includes it.
By their numbers in this assay, from the lowest: compounds 2, 1 and 3 (each within the scatter of the next).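

In this assay, a methoxy on an aromatic carbon ortho to a large group, taking 4-methoxyphenyl to 2,4-dimethoxyphenyl, gives a 1.3-fold higher number from compound 2 to compound 3 (0.12 log units; within the scatter). Measured against the plain phenyl, 2,4-dimethoxyphenyl gives a 1.2-fold higher number from compound 1 to compound 3 (0.06 log units; within the scatter), so this position, like the earlier methoxy step, shows no shift beyond the scatter, and neither does the pair of methoxy groups together. Nothing available gives a reason for this result. The compounds shown leave open whether an amine, a carboxylic acid or a longer alkoxy chain at this position would move the number beyond the scatter.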